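A few compounds are considered here, and "the series" means these few. Any claim that something is new, unique, unknown or untested is made for them only; others in the source may bear on it.

Compound 1 `Cc1ccc(-c2cs/c(=N/NC(=O)CSc3nnnn3-c3ccccc3)n2-c2ccccc2)cc1` carries the shared core of this small series. In an ADME assay on NIH3T3 cells (Mus musculus) for cytotoxicity, read by MTT assay, with a stated time of 24 h (on this read-out higher numbers stand for weaker inhibition and lower numbers for stronger inhibition), compound 1 gives only a limit, > 500 ug/mL, so its position is known as a boundary rather than a number (the limit of > 500 ug/mL in this assay, at which 1 of the 3 values shown sits). Compound 2 `O=C(CSc1nnnn1-c1ccccc1)N/N=c1/scc(-c2ccccc2)n1-c1ccccc1` gives 417 ug/mL in this assay. Compound 3 `O=C(CSc1nnnn1-c1ccccc1)N/N=c1/scc(-c2ccc(F)cc2)n1-c1ccccc1` gives 207 ug/mL in this assay. The measured steps each alter one group on an aromatic carbon: an at least 1.1-fold lower number from compound 1 to compound 2 (0.07 log units; that floor lies within the scatter); an at least 2.4-fold lower number from compound 1 to compound 3 (0.38 log units; beyond the scatter); a 2.0-fold lower number from compound 2 to compound 3 (0.30 log units; within the scatter).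

Compound 4 `Cc1ccc(-c2cs/c(=N/NC(=O)CSc3nnc(C)s3)n2-c2ccccc2)cc1` alters a different part of compound 1, the group attached to the sulfur: 5-methyl-1,3,4-thiadiazol-2-yl in place of 1-phenyl-1H-tetrazol-5-yl on a sulfur. Within the data shown here, none of the measured steps touches that sulfur-bound group, so they offer no direct guide to how large this step will be in this assay or in which direction it will run. What they do show is that the three measured compounds all sit in the same broad region of the scale, with only compound 3 clearly separated from compound 1. Compound 4 is therefore expected to show little movement from the boundary set by compound 1, an expected step of an at least 1.1-fold lower number from compound 1 to compound 4 (0.04 log units; that floor lies within the scatter). The value estimated for compound 4 is 450 ug/mL, with a range from 200 ug/mL to 1000 ug/mL.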

Compound 4, half-maximal inhibitory concentration: 373 ug/mL
Beside the measured number, compound 4's estimate is 1.2-fold (0.08 log units) above it, and the stated range covers the measured number.
By their numbers in this assay, from the lowest: compounds 3, 4 and 2 (each within the scatter of the next). At a limit, above all of these: compound 1.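

Among these compounds, this is the first change at the group on the sulfur: 5-methyl-1,3,4-thiadiazol-2-yl replaces 1-phenyl-1H-tetrazol-5-yl, which also removes the six-membered aromatic ring of carbon only, and in this assay the result is an at least 1.3-fold lower number from compound 1 to compound 4 (0.12 log units; that floor lies within the scatter). So the floor of this step gives no clear sign of change. This large swap of groups on the sulfur still leaves compound 4 with a measured number, 373 ug/mL. Compound 1 stands at a limit, and because of that limit only a floor can be read for this step, whose true size could be larger: the limit of > 500 ug/mL in this assay, at which 1 of the 4 values shown sits.

With only two groups shown on the sulfur, it remains open how the number would respond to a simple methyl or a longer alkyl chain there, or to an amine or a carboxylic acid in place of the methyl of the 5-methyl-1,3,4-thiadiazol-2-yl. As far as these compounds go, it is also open whether fluoro in place of methyl on an aromatic carbon would give a step of similar size when the sulfur carries 5-methyl-1,3,4-thiadiazol-2-yl.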